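A few compounds are considered here, and "the series" means these few. Any claim that something is new, unique, unknown or untested is made for them only; others in the source may bear on it.

The series has three numbers in a physicochemical assay for lipophilicity, measured as chromatographic lipophilicity, at pH 7.4; a higher number here means a more lipophilic compound, a lower number a more polar compound. Compound 1 `COc1cc(-c2nnc3n2CCCC3(c2ccc(Cl)c(Cl)c2)C(C)(C)O)ccc1-c1cnc(C)o1` gives 3.7, compound 2 `COc1cc(-c2nnc3n2CCCC3(Cc2ccc(F)c(F)c2)C(C)(C)O)ccc1-c1cnc(C)o1` gives 3 and compound 3 `COc1cc(-c2nnc3n2CCCC3(CO)Cc2ccc(F)c(F)c2)ccc1-c1cnc(C)o1` gives 2.5, which puts compound 2 second highest of the three.

Compound 4 `COc1cc(-c2nnc3n2CCCC3(Oc2ccc(F)c(Cl)c2)C(C)(C)O)ccc1-c1cnc(C)o1` has not yet been measured. It departs from compound 2 at one place, with 3-chloro-4-fluorophenoxy in place of 3,4-difluorobenzyl on a saturated ring carbon. The 1-hydroxy-1-methylethyl group stays.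

Within the data shown here, two measured steps bear on this change. The closer one is at the same carbon: 3,4-difluorobenzyl in place of 3,4-dichlorophenyl gave a number 0.70 log units lower from compound 1 to compound 2 (beyond the scatter), a modest step beyond the scatter. Read in reverse, it points upward when the 3,4-difluorobenzyl leaves. Among the measured compounds shown here, the entering group matches neither side of that step, however, and no measured compound carries a phenoxy group, so only part of that step is expected to carry over. The other step, hydroxymethyl in place of 1-hydroxy-1-methylethyl, gave a number 0.50 log units lower from compound 2 to compound 3 (beyond the scatter). It concerns the group that compound 4 retains, so it serves only as a guide to how large single changes are here.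

A modest rise is therefore expected, with an estimated size of a number 0.40 log units higher from compound 2 to compound 4 (beyond the scatter). For compound 4 the estimated value is 3.4, with an expected range of 3 to 3.8.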

Compound 4, distribution coefficient: 3.2
Beside the measured number, compound 4's estimate is 0.20 log units above it; the measured number falls inside the stated range.
By their numbers in this assay, from the lowest: compound 3; then compounds 2 and 4 (each within the scatter of the next); then compound 1.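

The change at the saturated ring carbon, two ring bonds from the ring nitrogen, gives a number 0.20 log units higher from compound 2 to compound 4 (within the scatter) in this assay and so leaves 3-chloro-4-fluorophenoxy and 3,4-difluorobenzyl indistinguishable here, although the entering group counts one hydrogen-bond acceptor and the leaving group none. Set against 3,4-dichlorophenyl at the same carbon, the 3-chloro-4-fluorophenoxy group gives a number 0.50 log units lower from compound 1 to compound 4 (beyond the scatter) and so, among the three groups now seen at this carbon with 1-hydroxy-1-methylethyl retained, only the 3,4-dichlorophenyl of compound 1 stands apart from the other two. No measured evidence accompanies these numbers to account for them.

The step from compound 2 to compound 4 alters the linking atom and the halogens on the ring together, so the compounds shown cannot separate the contribution of the oxygen link from that of the chlorine, and the effect of exchanging 1-hydroxy-1-methylethyl for hydroxymethyl is known only with the 3,4-difluorobenzyl group in place. On these data alone, how an amine or a carboxylic acid on the aromatic ring of the phenoxy group, or a longer chain such as phenethyl at this carbon, would read in this assay also stays open.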